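Working notes: from compound 2 to compound 3

The compounds below may be only part of what the source reports. "The series", "measured", "known", "first", "only" and "open" are said of these compounds alone.

Measured in a functional assay on LoVo cells (Homo sapiens) for inhibition, read by MTT assay, with a stated time of 24 h; a higher number here means a weaker inhibitor, a lower number a stronger inhibitor:
- compound 1 `CC1(C)[C@H]2CC[C@]1(C)N(Cc1cn(-c3ccccc3Cl)nn1)C(=O)C2`: 190 nM
- compound 2 `CC1(C)[C@H]2CC[C@]1(C)N(Cc1cn(-c3ccc(O)cc3)nn1)C(=O)C2`: 410 nM

For the measured compounds named here, of the two numbers so far, the higher belongs to compound 2 at 410 nM, making it the weaker inhibitor of the pair. The next entry is compound 3 `Cc1ccc(-n2cc(CN3C(=O)C[C@@H]4CC[C@@]3(C)C4(C)C)nn2)cc1`, with this difference from compound 2: methyl in place of hydroxy on an aromatic carbon. Put simply, the 4-hydroxyphenyl of compound 2 becomes the 4-methylphenyl of compound 3.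

Going by the values given here, only one measured step bears on this: a 2.2-fold higher number from compound 1 to compound 2 (0.33 log units; beyond the scatter). It is modest and comes from a swap of 4-hydroxyphenyl for 2-chlorophenyl on an aromatic nitrogen. Among the compounds with values here, no measured compound carries the methyl, so the evidence is indirect. On that single step, a small move toward a lower number is expected in this assay, no larger than the measured one. The step expected is a 1.6-fold lower number from compound 2 to compound 3 (0.21 log units; within the scatter). For compound 3 the estimated value is 250 nM, with an expected range of 100 nM to 600 nM.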

Compound 3, half-maximal inhibitory concentration: 50 nM
Beside the measured number, compound 3's estimate is 5.0-fold (0.70 log units) above it; the whole stated range lies above it.
By their numbers in this assay, from the lowest: compound 3; then compound 1; then compound 2.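

For the compounds shown here, at this position, para to a large group on a six-membered aromatic ring of carbon only, replacing hydroxy with methyl moves the number in this assay by a wide margin (an 8.2-fold lower number from compound 2 to compound 3 (0.91 log units; beyond the scatter)), so a change of a single heavy atom here can matter far more than the earlier compounds alone could show. The 4-methylphenyl also outperforms the 2-chlorophenyl (a 3.8-fold lower number from compound 1 to compound 3 (0.58 log units; beyond the scatter)), making compound 3 the strongest inhibitor of the three and showing that the better result of compound 1 over compound 2 did not mark the 2-chlorophenyl as the best aryl group in the series. No available measurement accounts for the size of these steps.

On these data alone, only hydroxy and methyl appear at this position, so it remains open whether the gain follows from having methyl there or from losing hydroxy, a question that a methoxy group, a fluorine atom, an ethyl group or an amine in the same place could help to settle. The 2-chlorophenyl and 4-methylphenyl groups differ in both substituent and placement, so the compounds shown also leave the separate contribution of each unresolved.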